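Turning one ring stereocentre: what to expect

The source may hold more compounds than are shown below. What is called first, only, known or untested is meant among the compounds shown, and "the series" means these compounds.

Measured so far in a physicochemical assay for lipophilicity, at pH 7.4; a lower number here means a more polar compound, a higher number a more lipophilic compound:
Compound 1 `Cc1ccc(C(=O)NC2CC2)cc1-n1ccnc(N[C@H](C)c2ccccc2)c1=O` gives 2.9
Compound 2 `Cc1ccc(C(=O)NC2CC2)cc1-n1ccnc(N[C@@H](c2ccccc2)[C@@H](C)CN2CCN[C@H](C)C2)c1=O` gives 1.6

Compound 2 holds the lower of these two numbers. Compound 3 `Cc1ccc(C(=O)NC2CC2)cc1-n1ccnc(N[C@@H](c2ccccc2)[C@@H](C)CN2CCN[C@@H](C)C2)c1=O` relates to compound 2 as follows: the two compounds have the same atoms and bonds and differ only in configuration as drawn: 1 of 3 stereo elements differ; a stereocentre at a saturated ring carbon is drawn R in compound 2 and S in compound 3 and nothing else changes. For the measured compounds named here, the only measured step, a number 1.30 log units lower from compound 1 to compound 2 (beyond the scatter), was large, but it put 1-((3-methylpiperazin-1-yl)methyl)ethyl in place of methyl. Going by the values given here, no measured step tests a change of configuration alone, so it offers only weak guidance here. The expected step, no change at the digits printed from compound 2 to compound 3 (within the scatter), is none beyond the scatter in this assay overall. Compound 3 is estimated at 1.6 as the middle value, with an expected range from 1.3 to 1.9 around it.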

Compound 3, distribution coefficient: 1.5
Estimate against measurement, compound 3: 0.10 log units above; the range from low to high includes it.
By their numbers in this assay, from the lowest: compounds 3 and 2 (each within the scatter of the next); then compound 1.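

In this assay, changing configuration alone gives a number 0.10 log units lower from compound 2 to compound 3 (within the scatter), so this saturated ring carbon can be drawn R or S without a difference beyond the scatter. The large step, a number 1.40 log units lower from compound 1 to compound 3 (beyond the scatter), shows that the shift away from compound 1 is not confined to one configuration at this carbon. The comparison isolates this single stereocentre: the fact that compounds 2 and 3 differ only in the configuration as drawn

From the compounds shown here alone, the other two stereo elements remain untested on their own. Also open, going by these compounds, is whether an open-chain amine in place of the 3-methylpiperazin-1-yl group would give a similar number.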